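Notes on the aryl swap at the aromatic nitrogen

A few compounds are considered here, and "the series" means these few. Any claim that something is new, unique, unknown or untested is made for them only; others in the source may bear on it.

Compound 3 `COc1ccc(OC)c(-n2nncc2CN2C(=O)C3(C(C#N)=C(N)Oc4c(N)cc5nc6ccccc6nc5c43)c3ccccc32)c1` gives 28100 nM in a functional assay on A549 cells (Homo sapiens) for antiproliferative activity, read by MTT assay, with a stated time of 48 h (on this read-out lower numbers stand for stronger inhibition and higher numbers for weaker inhibition), the higher of the two numbers obtained so far. Its nearest neighbour is compound 1 `Cc1cccc(-n2nncc2CN2C(=O)C3(C(C#N)=C(N)Oc4c(N)cc5nc6ccccc6nc5c43)c3ccccc32)c1`, which gives 12300 nM in this assay, so that a 2.3-fold higher number from compound 1 to compound 3 (0.36 log units; beyond the scatter). For compound 2 `N#CC1=C(N)Oc2c(N)cc3nc4ccccc4nc3c2C12C(=O)N(Cc1cnnn1-c1ccc(Cl)cc1)c1ccccc12` the read-out in this assay is a limit, > 50000 nM, and not a number. One of the three results is thus (the limit of > 50000 nM in this assay, at which 1 of the 3 values shown sits).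

Compound 4 `N#CC1=C(N)Oc2c(N)cc3nc4ccccc4nc3c2C12C(=O)N(Cc1cnnn1-c1c(Cl)cc(Cl)cc1Cl)c1ccccc12` differs from compound 3 in one place: 2,4,6-trichlorophenyl in place of 2,5-dimethoxyphenyl on an aromatic nitrogen. Among the compounds with values here, two measured steps bear on this change. A chlorine-bearing ring on the same nitrogen already gave an at least 4.0-fold higher number from compound 1 to compound 2 (0.60 log units; beyond the scatter), a step beyond the scatter, whereas an at least 1.7-fold lower number from compound 2 to compound 3 (0.25 log units; that floor lies within the scatter), whose floor lies within the scatter. A further rise in the number is therefore expected, and the reported result may again be a limit. The expected step is a 1.8-fold higher number from compound 3 to compound 4 (0.25 log units; within the scatter). Compound 4 is estimated at 50000 nM in this assay, within a range from 15000 nM to 160000 nM.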

Compound 4, half-maximal inhibitory concentration: > 50000 nM
Compound 4 gave a limit, no number; the forecaster's own chance of this, stated with the estimate: 55%; the middle value sits exactly at the limit.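

Both chlorine-bearing aryl groups now end at the same limit in this assay: the limit of > 50000 nM in this assay, at which 2 of the 4 values shown sit. Measured from the 3-methylphenyl group, the change to 2,4,6-trichlorophenyl gives an at least 4.0-fold higher number from compound 1 to compound 4 (0.60 log units; beyond the scatter), while measured from 2,5-dimethoxyphenyl it gives an at least 1.7-fold higher number from compound 3 to compound 4 (0.25 log units; that floor lies within the scatter). The step between the two chlorine-bearing compounds cannot be read, so the results do not tell whether the additional chlorine atoms on the ring change the read-out at all.

All the compounds shown carry an aryl group on this nitrogen, so it stays open what a carboxylic acid or an amine on that ring, or a longer alkyl chain in its place, would do to the number. Also open, as far as these compounds go, is how a 3-chlorophenyl group would compare with the 3-methylphenyl group of compound 1, a change in one place only.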